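The compounds below may be only part of what the source reports. "The series", "measured", "known", "first", "only" and "open" are said of these compounds alone.

Among the measured compounds shown here, compound 1 `COc1cc(NC(C)CCCNC(=O)/C=C/c2ccccc2)c2ncccc2c1` is the only compound with a measured number in an ADME assay on L6 cells (Rattus norvegicus) for cytotoxicity, read by resazurin assay, with a stated time of 70 h; on this read-out lower numbers stand for stronger inhibition and higher numbers for weaker inhibition; compound 1 gives 7.2 ug/mL. Compound 2 `COc1cc(NC(C)CCCNC(=O)/C=C/c2ccc(OC)c(OC)c2)c2ncccc2c1` has only a limit in this assay: compound 2 gives > 100 ug/mL, a limit and not a number (the limit of > 100 ug/mL in this assay, at which 1 of the 2 values shown sits). For the measured compounds named here, the step of an at least 13-fold higher number from compound 1 to compound 2 (1.14 log units; beyond the scatter) is the sole measured comparison, and it bears on the present change only in part, since it kept the phenyl and altered its substitution rather than exchanging the whole group on the carbonyl carbon. Compound 3 `COc1cc(NC(C)CCCNC(=O)Nc2ccc(O)cc2)c2ncccc2c1` differs from compound 1 by (4-hydroxyphenyl)amino in place of 2-phenylethenyl on a carbonyl carbon. Because an at least 13-fold higher number from compound 1 to compound 2 (1.14 log units; beyond the scatter) moved towards weaker cytotoxicity when the group on this carbonyl carbon was varied, a higher number is expected for compound 3, though with less confidence than for a closer analogue of compound 2. Compound 3 is expected at 40 ug/mL, between 10 ug/mL and 100 ug/mL, an expected step of a 5.6-fold higher number from compound 1 to compound 3 (0.74 log units; beyond the scatter).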

Compound 3, half-maximal inhibitory concentration: 14.8 ug/mL
The estimate for compound 3 lay 2.7-fold (0.43 log units) above the measured number; low and high end bracket the measured number.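

In this assay, (4-hydroxyphenyl)amino in place of 2-phenylethenyl on a carbonyl carbon gives a 2.1-fold higher number from compound 1 to compound 3 (0.31 log units; beyond the scatter). The number at this position therefore moves not only when the phenyl of the 2-phenylethenyl group is substituted but also when the whole group is exchanged, and both listed steps from compound 1 point towards higher numbers, although this one is modest. Compound 2 still stands as a limit and not a number: the limit of > 100 ug/mL in this assay, at which 1 of the 3 values shown sits.

The hydroxyl and the amino nitrogen enter together, so the compounds shown do not separate their contributions, and it stays open where plain phenylamino would fall. Also open, going by these compounds, is how the number would respond to a carboxylic acid or an amine on that phenyl ring, or to a longer chain on the carbonyl carbon.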